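The source may hold more compounds than are shown below. What is called first, only, known or untested is meant among the compounds shown, and "the series" means these compounds.

Measured compounds:
Compound 1: `C/C=C1/[C@H](O[C@@H]2O[C@H](CO)[C@@H](O)[C@H](O)[C@H]2O)OC=C(C(=O)OC)[C@H]1CC(=O)OC[C@H]1O[C@@H](OCCc2ccccc2)[C@H](O)[C@@H](O)[C@@H]1O`, 65700 nM
Compound 2: `C/C=C1/[C@H](O[C@@H]2O[C@H](CO)[C@@H](O)[C@H](O)[C@H]2O)OC=C(C(=O)OC)[C@H]1CC(=O)OC[C@H]1O[C@@H](Oc2ccc(O)cc2)[C@H](O)[C@@H](O)[C@@H]1O`, 58300 nM

In a functional assay on RAW264.7 cells (Mus musculus) for inhibition, read by Griess assay, with a stated time of 24 h (a higher number here means a weaker inhibitor, a lower number a stronger inhibitor), compound 1 gives 65700 nM, the highest of the two numbers shown. Compound 2 gives 58300 nM, and the step of a 1.1-fold lower number from compound 1 to compound 2 (0.05 log units; within the scatter) falls within the scatter, so the two compounds cannot be told apart on these numbers.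

Compound 3 is `C/C=C1/[C@H](O[C@@H]2O[C@H](CO)[C@@H](O)[C@H](O)[C@H]2O)OC=C(C(=O)OC)[C@H]1CC(=O)OC[C@H]1O[C@@H](OCCc2ccc(O)c(O)c2)[C@H](O)[C@@H](O)[C@@H]1O`. Compared with compound 1 the change is 3,4-dihydroxyphenyl in place of phenyl on a saturated chain carbon, two bonds along the chain from an oxygen on a saturated carbon. Among the measured compounds shown here, the only measured step that bears on this part of the molecule is a 1.1-fold lower number from compound 1 to compound 2 (0.05 log units; within the scatter), which replaced the whole phenethyl group and still produced no change beyond the scatter. For the measured compounds named here, no measured pair adds hydroxyl groups to a phenyl ring while keeping the chain. The step expected for compound 3 is therefore a 1.2-fold lower number from compound 1 to compound 3 (0.08 log units; within the scatter), no more than the scatter. Compound 3 is estimated at 55000 nM, within a range from 22000 nM to 140000 nM.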

Compound 3, half-maximal inhibitory concentration: 48900 nM
Estimate against measurement, compound 3: 1.1-fold (0.05 log units) above, within the range that was stated.
By their numbers in this assay, from the lowest: compounds 3, 2 and 1 (each within the scatter of the next).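

Keeping the chain and adding the two ring hydroxyl groups, a change no earlier pair tested, gives no step beyond the scatter in this assay: a 1.3-fold lower number from compound 1 to compound 3 (0.13 log units; within the scatter). Replacing 4-hydroxyphenyl with 2-(3,4-dihydroxyphenyl)ethyl on the same oxygen gives a 1.2-fold lower number from compound 2 to compound 3 (0.08 log units; within the scatter), so phenethyl, 4-hydroxyphenyl and 2-(3,4-dihydroxyphenyl)ethyl cannot be told apart at this position. No accompanying measurement offers an explanation for this flat result.

From the compounds shown here alone, whether the flat result holds for other groups remains open, such as an amine or a carboxylic acid in place of the ring hydroxyl groups, or a longer chain between the oxygen and the ring. All three compounds share one core, so they also leave open how much of the number comes from that core and how much from the group at this position.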